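Exposure notes on compound 4 in the monkey series

The source may report more compounds than this note shows. Statements on the series, on what has been measured and on what is new or still open speak of the compounds shown alone.

Three compounds have numbers in an ADME assay on the whole organism (Macaca fascicularis) for pharmacokinetics, read by LC-MS, using cassette dosing, at a dose of 1 mg/kg by the oral route; a higher number here means more compound in the circulation at the dose given, a lower number less compound in the circulation. Compound 1 `CCCCN(c1nc2ccccc2o1)[C@H](C)c1ccc(-c2ccccc2-c2nnn[nH]2)cc1` gives 29.2 nM in this assay. Compound 2 `CCCCN(c1nc2c(NS(C)(=O)=O)cccc2o1)[C@H](C)c1ccc(-c2ccccc2-c2nnn[nH]2)cc1` gives 49.9 nM in this assay. Compound 3 `Cc1ccc(-c2nc(=O)o[nH]2)c(-c2ccc([C@@H](C)N(CC3CC3)c3nc4c(C(=O)O)cccc4o3)cc2)c1`, which differs from the other two at several points, gives 2920 nM in this assay. Compound 2 thus stands second highest of the three numbers: its nearest neighbour is compound 1, within the scatter, and its furthest is compound 3, beyond the scatter.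

Compound 4 `CCCCN(c1nc2c(-c3nccn3C)cccc2o1)[C@H](C)c1ccc(-c2ccccc2-c2nnn[nH]2)cc1` has not yet been measured in this assay. It differs from compound 2 in one place: 1-methyl-1H-imidazol-2-yl in place of methanesulfonamido on an aromatic carbon.

For the measured compounds named here, only one measured step touches the same position of the shared core: a 1.7-fold higher number from compound 1 to compound 2 (0.23 log units; within the scatter). Going by the values given here, no measured pair shows a five-membered aromatic ring entering at this position, so the size of the step to compound 4 cannot be read directly from the data. Among the compounds with values here, since the one change seen at this position stayed within the scatter, the step to compound 4 is expected to be small as well, in either direction, and the estimated step is a 1.2-fold lower number from compound 2 to compound 4 (0.10 log units; within the scatter). Compound 4 is therefore expected to give about 40 nM in this assay, with a range from 10 nM to 160 nM.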

Compound 4, maximal plasma concentration: 154 nM
For compound 4 the middle estimate is 3.9-fold (0.59 log units) below the measured one; the range from low to high includes it.
By their numbers in this assay, from the lowest: compounds 1 and 2 (each within the scatter of the next); then compound 4; then compound 3.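

In this assay, the aromatic carbon on the shared core now shows steps beyond the scatter, with a 3.1-fold higher number from compound 2 to compound 4 (0.49 log units; beyond the scatter) for 1-methyl-1H-imidazol-2-yl in place of methanesulfonamido and a 5.3-fold higher number from compound 1 to compound 4 (0.72 log units; beyond the scatter) for the same group in place of hydrogen. For the compounds shown here, the only earlier change here, a 1.7-fold higher number from compound 1 to compound 2 (0.23 log units; within the scatter) for methanesulfonamido in place of hydrogen, stayed within the scatter, and the new steps show that the group on this carbon can move the maximal plasma concentration beyond the scatter. The entering group has one five-membered aromatic ring and no hydrogen-bond donor, whereas methanesulfonamido has no ring and one hydrogen-bond donor, but no measurement available here explains the higher number.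

From the compounds shown here alone, it remains open whether the step belongs to this particular group or extends to other substituents on the same carbon, such as a primary amine, a phenyl ring or the imidazole without its methyl. Going by these compounds, it also remains open whether a step of this size would persist with a longer chain in place of the butyl group on the shared core.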